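Methylated pyrazole variant of an imidazoline aryl ether

The source may report more compounds than this note shows. Statements on the series, on what has been measured and on what is new or still open speak of the compounds shown alone.

Measured compounds:
Compound 1 `c1ccc(-c2cc[nH]n2)c(OCC2=NCCN2)c1`: 119%
Compound 2 `c1ccc(-c2ccns2)c(OCC2=NCCN2)c1`: 99%

In a functional assay with Alpha-1A adrenergic receptor (Homo sapiens) as the target, read by calcium flux (a higher number here means a larger maximal response, a lower number a smaller maximal response), compound 1 gives 119%, the highest of the two numbers recorded. Within the data shown here, its nearest neighbour is compound 2, and the one step measured is a number 20 percentage points lower from compound 1 to compound 2 (beyond the scatter), a modest fall that lies beyond the scatter.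

Compound 3 `Cn1nccc1-c1ccccc1OCC1=NCCN1` has not yet been measured in this assay. It differs from compound 1 in one place: 1-methyl-1H-pyrazol-5-yl in place of 1H-pyrazol-3-yl on an aromatic carbon. The change bears some resemblance to the measured step in that the same group on the same aromatic carbon is exchanged for another five-membered aromatic ring with 2 hetero atoms, and that step from compound 1 to compound 2 lowered the maximum modestly. On that single precedent a modest decrease, or none beyond the scatter, is expected for compound 3 in this assay.

The estimated value for compound 3 is 105%, with an expected range from 85% to 125%. The step this estimate implies is a number 14 percentage points lower from compound 1 to compound 3 (beyond the scatter), an expected change of modest size.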

Compound 3, largest response reached (reported as maximum), in percent of the reference or control that the assay uses: 107%
Beside the measured number, compound 3's estimate is 2 percentage points below it; low and high end bracket the measured number.
By their numbers in this assay, from the lowest: compounds 2 and 3 (each within the scatter of the next); then compound 1.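

In this assay the exchange of 1H-pyrazol-3-yl for 1-methyl-1H-pyrazol-5-yl gives a number 12 percentage points lower from compound 1 to compound 3 (beyond the scatter) and so adds a second ring at this aromatic carbon that falls short of compound 1, this time a ring with no hydrogen-bond donor. The other new step, a number 8 percentage points higher from compound 2 to compound 3 (within the scatter), places the 1-methyl-1H-pyrazol-5-yl and 1,2-thiazol-5-yl groups within the scatter of each other, so the three compounds do not separate these two replacements. Nothing shown here explains the differences.

The compounds shown do not separate the loss of the hydrogen-bond donor from the gain of the methyl group. They also leave open how a group without a ring at this carbon, such as an amine or a carboxylic acid, would behave in this assay.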